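The source may hold more compounds than are shown below. What is called first, only, known or untested is meant among the compounds shown, and "the series" means these compounds.

Three compounds sharing one core have been examined in an ADME assay on HeLa Rh cells (Homo sapiens) for cytotoxicity, read by microscopy; a lower number here means that less compound is tolerated, a higher number that more compound is tolerated. Compound 1 `COc1cc(CC(O)c2ccc(-c3ccc(C=O)cc3)cc2)c([N+](=O)[O-])cc1OC` gives only a limit of the assay in this assay, > 245000 nM. Compound 2 `COc1cc(CC(O)c2ccc(-c3ccc(C)cc3)cc2)c([N+](=O)[O-])cc1OC` gives 4700 nM in this assay, and compound 3 `COc1cc(CC(O)c2ccc(-c3ccc(Cl)cc3)cc2)c([N+](=O)[O-])cc1OC` gives 4100 nM. The move from formyl to methyl produced an at least 52-fold lower number from compound 1 to compound 2 (1.71 log units; beyond the scatter), and the move from formyl to chloro produced an at least 59-fold lower number from compound 1 to compound 3 (1.77 log units; beyond the scatter). Between the two non-limit values the picture is flat: a 1.1-fold lower number from compound 2 to compound 3 (0.06 log units; within the scatter). Compound 2 therefore holds the higher of the two numbers shown in this assay, with compound 3 as its nearest neighbour, the two lying within the scatter of each other.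

The step now followed leads to compound 4 `COc1cc(CC(O)c2ccc(-c3ccc(Br)cc3)cc2)c([N+](=O)[O-])cc1OC`. The change is bromo in place of methyl on an aromatic carbon. For the measured compounds named here, of the measured steps, the one from compound 2 to compound 3 bears most directly on it, since it also exchanges methyl for a single-atom substituent at the same place, and that step stayed within the scatter. The two large steps from compound 1 concern the departure of formyl and do not speak to this exchange. Accordingly no step beyond the scatter is expected in this assay, a 1.2-fold lower number from compound 2 to compound 4 (0.07 log units; within the scatter). Compound 4 is estimated at 4000 nM, in a range from 1800 nM to 9000 nM.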

Compound 4, half-maximal cytotoxic concentration: 4300 nM
Beside the measured number, compound 4's estimate is 1.1-fold (0.03 log units) below it, within the range that was stated.
By their numbers in this assay, from the lowest: compounds 3, 4 and 2 (each within the scatter of the next). At a limit, above all of these: compound 1.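

With bromo on this aromatic carbon, para to a large group, the exchange for methyl gives a 1.1-fold lower number from compound 2 to compound 4 (0.04 log units; within the scatter), and the exchange for chloro gives a 1.0-fold higher number from compound 3 to compound 4 (0.02 log units; within the scatter). Compound 2, compound 3 and compound 4 thus form a set of three in this assay, each within the scatter of the other two, so that methyl, chloro and bromo cannot be told apart here, which a single pair could not show. Formyl now stands apart from a third replacement, in an at least 56-fold lower number from compound 1 to compound 4 (1.75 log units; beyond the scatter), although that step starts from a value of compound 1 that is a limit and not a number: the limit of > 245000 nM in this assay, at which 1 of the 4 values shown sits.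

The compounds shown leave open whether an amine, a carboxylic acid or a hydroxymethyl group at this position would fall with the methyl, chloro and bromo compounds or with the formyl compound 1. They also leave open whether a longer chain here, such as propyl or butyl, would stay level with those three, and they do not tell what sets formyl apart.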